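Swapping methyl for chloro on the benzyl arm of two cores

This account rests on a few compounds, and the source may have more. Where it says the series, first, only, none or still open, it means among the compounds named here.

Measured compounds:
Compound 1 `COC(=O)C(C(=O)OC)C1CC(=O)C=CC12OCC(=O)N2Cc1ccc(C)cc1` gives 340 nM in a functional assay on MDA-MB-231 cells (Homo sapiens) for inhibition; a lower number here means a stronger inhibitor, a higher number a weaker inhibitor.
Compound 2 `COC(=O)C(C(=O)OC)C1CC(=O)C=CC12OCC(=O)N2Cc1ccc(Cl)cc1` gives 380 nM in this assay.
Compound 3 `CCSC1CC(=O)CC(SCC)C12OCC(=O)N2Cc1ccc(C)cc1` gives 1360 nM in this assay.

Compound 1 and compound 2 share one core and differ only by chloro in place of methyl on an aromatic carbon; the step of a 1.1-fold higher number from compound 1 to compound 2 (0.05 log units; within the scatter). Compound 3 carries a different core; how the two cores differ is not broken down here, and in this assay compound 3 stands at the highest number of the three.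

Compound 4 `CCSC1CC(=O)CC(SCC)C12OCC(=O)N2Cc1ccc(Cl)cc1` is not yet measured. It differs from compound 3 by chloro in place of methyl on an aromatic carbon, the same change that turned compound 1 into compound 2, placed the same way. Because that step a 1.1-fold higher number from compound 1 to compound 2 (0.05 log units; within the scatter) stayed within the scatter, a similar step is expected from compound 3 to compound 4, a 1.1-fold higher number from compound 3 to compound 4 (0.04 log units; within the scatter). Compound 4 is therefore estimated at 1500 nM, likely between 700 nM and 3200 nM in this assay.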

Compound 4, half-maximal inhibitory concentration: 260 nM
Beside the measured number, compound 4's estimate is 5.8-fold (0.76 log units) above it; measured number below the stated range.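

On the core of compound 3, chloro in place of methyl gives a 5.2-fold lower number from compound 3 to compound 4 (0.72 log units; beyond the scatter) in this assay. The size of this step therefore depends on the core that carries it, and a step read on one core cannot simply be copied to the other: the same change on two cores in this assay, a 1.1-fold higher number (0.05 log units; within the scatter) from compound 1 to compound 2 and a 5.2-fold lower number (0.72 log units; beyond the scatter) from compound 3 to compound 4, 5.8-fold (0.77 log units) apart, beyond the scatter of two such steps

These two pairs do not show why the cores respond differently, and they set no rule for any further core or any other swap in this series.

Going by these compounds, it remains open whether a methoxy group or a carboxylic acid in place of the chloro would behave differently on the two cores. Also open, on these data alone, is how a longer chain in place of the ethyl groups on sulfur would alter the step.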